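A few compounds are considered here, and "the series" means these few. Any claim that something is new, unique, unknown or untested is made for them only; others in the source may bear on it.

Compound 1, `COc1cccc(CNCCCNc2ccnc3cc(Cc4cccc(C(F)(F)F)c4)ccc23)c1O`, gives 23 10^-6 cm/s in an ADME assay for permeability, using PAMPA, with a stated time of 30 min, at pH 7.4; on this read-out higher numbers stand for higher permeability and lower numbers for lower permeability. Compound 2, `COc1cccc(CNCCCNc2ccnc3cc(CC(C)C)ccc23)c1O`, gives 23 10^-6 cm/s in this assay, so compound 2 stands level with compound 1 on this read-out. Within the data shown here, the one measured step, no change at the digits printed from compound 1 to compound 2 (within the scatter), replaced a 3-(trifluoromethyl)phenyl group with an isopropyl group on a saturated chain carbon bound to an aromatic carbon and left the read-out unchanged within the scatter.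

Compound 3, `COc1cccc(CNCCCNc2ccnc3cc(CC4CCCCC4)ccc23)c1O`, is not yet measured. It differs from compound 2 in the same place: cyclohexyl in place of isopropyl on a saturated chain carbon bound to an aromatic carbon. The step from compound 1 to compound 2 is the only one that bears on this change, since it exchanged groups on the same saturated chain carbon, and it was flat. On that basis compound 3 is expected to show no step beyond the scatter in this assay, with an expected change of no change at the digits printed from compound 2 to compound 3 (within the scatter). The estimate for compound 3 in this assay is therefore 23 10^-6 cm/s, with a range from 12 10^-6 cm/s to 42 10^-6 cm/s.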

Compound 3, apparent permeability: 23 10^-6 cm/s
Beside the measured number, compound 3's estimate shows no gap at the digits printed, within the range that was stated.
By their numbers in this assay, from the lowest: compounds 1, 2 and 3 (each within the scatter of the next).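

With cyclohexyl in place of isopropyl on a saturated chain carbon bound to an aromatic carbon, this assay shows no change at the digits printed from compound 2 to compound 3 (within the scatter) for this exchange, and cyclohexyl in place of 3-(trifluoromethyl)phenyl shows no change at the digits printed from compound 1 to compound 3 (within the scatter) in the same read-out. The earlier pair had set only isopropyl against 3-(trifluoromethyl)phenyl, whereas the level reading now also holds for a group with a six-membered non-aromatic ring of carbon only. Across these three compounds, the group at this place can therefore be exchanged in either of the new ways, including the rise from 3 heavy atoms to 6 heavy atoms in the step from isopropyl to cyclohexyl, without a step beyond the scatter, and none of the three goes against this.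

Isopropyl and cyclohexyl both carry no hydrogen-bond donors, no hydrogen-bond acceptors and no net charge, so it remains open whether an amine, a carboxylic acid or a longer chain at this place would also leave the read-out level. Nothing available explains why these three groups read alike.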